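The compounds below may be only part of what the source reports. "The series", "measured", "known", "first", "only" and "open" are said of these compounds alone.

Working notes on the series.

Compound 1 `COc1ccc(C(=O)Nc2cc(Nc3nccc(-c4cn(C)c5ccccc45)n3)c(OC)cc2N(C)C)nc1` gives 2130 nM in a functional assay on NCI-H1975 cells (Homo sapiens) for antiproliferative activity, read by MTT assay, with a stated time of 72 h; a lower number here means a stronger inhibitor, a higher number a weaker inhibitor. Compound 2 `COc1cc(N(C)C)c(NC(=O)c2ccncn2)cc1Nc1nccc(-c2cn(C)c3ccccc23)n1` gives 1250 nM in this assay. The change between them is pyrimidin-4-yl in place of 5-methoxypyridin-2-yl on a carbonyl carbon, and the step is a 1.7-fold lower number from compound 1 to compound 2 (0.23 log units; within the scatter). Compound 3 `COc1ccc(C(=O)Nc2cc(Nc3nc(-c4cn(C)c5ccccc45)c4cccnc4n3)c(OC)cc2N(C)CCN(C)C)nc1` gives 1160 nM in this assay; the difference between the core of compound 3 and the core of compound 1 is not broken down here, and the values of compound 3 and compound 2 lie within the scatter of each other. Compound 4 `COc1cc(N(C)CCN(C)C)c(NC(=O)c2ccncn2)cc1Nc1nc(-c2cn(C)c3ccccc23)c2cccnc2n1` is not yet measured. It differs from compound 3 by pyrimidin-4-yl in place of 5-methoxypyridin-2-yl on a carbonyl carbon, the same change as from compound 1 to compound 2, at the same place. The step in this assay is expected to be a 1.5-fold lower number from compound 3 to compound 4 (0.17 log units; within the scatter), resting on the step of a 1.7-fold lower number from compound 1 to compound 2 (0.23 log units; within the scatter) seen for the same change. Compound 4 is therefore estimated to give 780 nM in this assay, between 390 nM and 1600 nM.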

Compound 4, half-maximal inhibitory concentration: 1090 nM
For compound 4 the middle estimate is 1.4-fold (0.15 log units) below the measured one, and the stated range covers the measured number.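

Pyrimidin-4-yl in place of 5-methoxypyridin-2-yl on a carbonyl carbon gives a 1.1-fold lower number from compound 3 to compound 4 (0.03 log units; within the scatter) in this assay. Set beside the earlier step on the other core, the change shows no detectable difference between the two cores: the same change on two cores in this assay, a 1.7-fold lower number (0.23 log units; within the scatter) from compound 1 to compound 2 and a 1.1-fold lower number (0.03 log units; within the scatter) from compound 3 to compound 4, 1.6-fold (0.20 log units) apart, within the scatter of two such steps. Going by these compounds alone, neither step lies beyond the scatter, so this shows only that the change behaves alike on these two cores within the scatter; it does not show that the change itself moves the number on either core, and two cores support no rule for the series.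

Open, on these data alone, is what a group other than these two does on the carbonyl carbon, for instance an unsubstituted phenyl, a morpholine or a longer alkyl chain. Also open, as far as these compounds go, is whether the step stays the same on a third core.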